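The source may report more compounds than this note shows. Statements on the series, on what has been measured and on what is new or still open speak of the compounds shown alone.

Measured compounds:
- Compound 1, `N=C(NCc1ccccc1)[C@@H]1CCC(=O)N1Cc1ccc(F)cc1`, in a functional assay on SH-SY5Y cells (Homo sapiens) for cytotoxicity, read by MTT assay, with stated times of 8 h, 30 min and 12 h, tested at 0.5 uM (on this read-out lower numbers stand for a weaker effect and higher numbers for a stronger effect at the one concentration tested), compound 1 gives 23.3%.
- Compound 2, `COc1ccc(CNC(=N)[C@@H]2CCC(=O)N2Cc2ccc(F)cc2)cc1`, in this assay compound 2 gives 36.7%.

Among the measured compounds shown here, compound 2 stands highest of the two numbers available; the only neighbour is compound 1, and the step of a number 13.4 percentage points higher from compound 1 to compound 2 (beyond the scatter) lies beyond the scatter but is modest in size. That step brings methoxy in place of hydrogen on an aromatic carbon of the benzyl group attached to the amidine, a different place from the change now considered.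

Compound 3, `COc1ccc(CNC(=N)[C@@H]2CCC(=O)N2Cc2ccc(C)cc2)cc1`, is not yet measured. It differs from compound 2 by methyl in place of fluoro on an aromatic carbon, on the other benzyl group, the one on the lactam nitrogen. For the measured compounds named here, no measured step touches this position or exchanges fluoro for methyl, so nothing among the available numbers bears on it directly; the one known step shows only that a single small substituent change at an aromatic carbon of this series moved the read-out modestly. Going by the values given here, with no comparable precedent, the expected step of a number 0.7 percentage points lower from compound 2 to compound 3 (within the scatter) in this assay is none beyond the scatter, in either direction. Compound 3 is therefore estimated at 36%, with a range from 22% to 50%.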

Compound 3, a percentage reported as activity, at one concentration (the size of the read-out at that concentration, not a potency): 21.9%
Compound 3: middle estimate off by 14.1 percentage points, on the high side; the whole stated range lies above it.
By their numbers in this assay, from the lowest: compounds 3 and 1 (each within the scatter of the next); then compound 2.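

In this assay, among the compounds shown here, methyl in place of fluoro gives a number 14.8 percentage points lower from compound 2 to compound 3 (beyond the scatter), so this place on the 4-fluorobenzyl group, which the earlier compounds left unchanged, does affect the read-out. The exchange involves one heavy atom on each side, with no ring, hydrogen-bond donor, hydrogen-bond acceptor or net charge entering or leaving, yet its step is beyond the scatter and modest in size, as is the earlier step on the other benzyl group, though it runs in the opposite direction. No measurement at hand bears on what lies behind this step.

The compounds shown leave open whether other groups at this place, such as chloro, an amine or a carboxylic acid, would give numbers nearer to compound 2 or to compound 3, since fluoro and methyl are the only two groups seen there. They also leave open whether the methoxy change, which gave a number 13.4 percentage points higher from compound 1 to compound 2 (beyond the scatter) with the 4-fluorobenzyl group present, would have a similar effect with the 4-methylbenzyl group, and how any of these single-concentration numbers would relate to potency.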